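A Fluorine Added to the Methylphenyl Ring of Compound 2

The source may report more compounds than this note shows. Statements on the series, on what has been measured and on what is new or still open speak of the compounds shown alone.

Compound 2 `COc1ccc(-n2cnc3cnc(-c4ccccc4C)cc32)cc1OC` belongs to a set of three compounds sharing one core. In an ADME assay on S9 fraction from liver (Mus musculus) for metabolic stability, read by LC-MS, using NADPH, with a stated time of 45 min, tested at 3 uM, in the presence of a further agent that is not named here (a higher number here means that the liver removes a larger share of the compound in one pass, a lower number that the liver removes a smaller share), compound 2 gives 1, level with compound 3 `COc1ccc(-n2cnc3cnc(-c4ccccc4OC(F)(F)F)cc32)cc1OC`, which gives 1; the step of no change at the digits printed from compound 2 to compound 3 (within the scatter) lies within the scatter. Compound 1 `COc1ccc(-n2cnc3cnc(Nc4cccc(NS(C)(=O)=O)c4)cc32)cc1OC`, bearing a different substituent on the core, gives 0.58, the lowest of the three. Compound 4 `COc1ccc(-n2cnc3cnc(-c4ccc(F)cc4C)cc32)cc1OC` differs from compound 2 by fluoro in place of hydrogen on an aromatic carbon. For the measured compounds named here, the only measured step bearing on this change is no change at the digits printed from compound 2 to compound 3 (within the scatter), which left the number where it stood. A step of a number 0.030 lower from compound 2 to compound 4 (within the scatter) is therefore expected, none beyond the scatter. Compound 4 is estimated at 0.97, with a range from 0.88 to 1.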

Compound 4, hepatic extraction ratio: 1
For compound 4 the middle estimate is 0.030 below the measured one, within the range that was stated.
By their numbers in this assay, from the lowest: compound 1; then compounds 2, 3 and 4 (each within the scatter of the next).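

In this assay, fluoro on the aromatic carbon para to a large group and meta to a methyl group leaves the extraction ratio with no change at the digits printed from compound 2 to compound 4 (within the scatter). This is a second place on the ring, apart from the methyl group exchanged in compound 3, where a change does not lower a number already at the whole, as compound 2 stands at 1. Nothing shown explains this result. As far as these compounds go, whether an amine or a carboxylic acid on this carbon would lower the number remains open, as does the effect of fluoro on a compound starting below the whole.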